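Aryl replacement on the ring amide nitrogen of the core

A few compounds are considered here, and "the series" means these few. Any claim that something is new, unique, unknown or untested is made for them only; others in the source may bear on it.

Measured so far:
Compound 1, `CC(C)[C@@H]1CC[C@@H](C)C[C@@]12N(C)C(=O)[C@@H]1[C@H]3C(=O)N(C)C(=O)[C@H]3ON12`: 70.3%
Compound 2, `CC(C)[C@@H]1CC[C@@H](C)C[C@@]12N(C)C(=O)[C@@H]1[C@H]3C(=O)N(c4ccccc4)C(=O)[C@H]3ON12`: 58.6%

In a functional assay, read by spectrophotometry, with a stated time of 2 h, tested at 2.5 mg/mL (on this read-out lower numbers stand for a weaker effect and higher numbers for a stronger effect at the one concentration tested), compound 1 gives 70.3%, the higher of the two numbers; the nearest is compound 2, and the step of a number 11.7 percentage points lower from compound 1 to compound 2 (beyond the scatter) lies beyond the scatter. Compound 3, `Cc1ccc(N2C(=O)[C@H]3[C@H](ON4[C@@H]3C(=O)N(C)[C@@]43C[C@H](C)CC[C@H]3C(C)C)C2=O)c(C)c1`, carries the change 2,4-dimethylphenyl in place of methyl on an amide-type nitrogen in a ring and has not yet been tested in this assay. For the measured compounds named here, the only measured step that bears on it is a number 11.7 percentage points lower from compound 1 to compound 2 (beyond the scatter), a modest lowering when phenyl replaced methyl on the same amide-type nitrogen in a ring. Because of a number 11.7 percentage points lower from compound 1 to compound 2 (beyond the scatter) a modest lowering is expected for compound 3 as well, with the 2,4-dimethylphenyl group, and the step of a number 15.3 percentage points lower from compound 1 to compound 3 (beyond the scatter) is the estimate. Compound 3 is therefore expected to give 55% in this assay, within a range from 40% to 68%.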

Compound 3, a percentage reported as activity, at one concentration (the size of the read-out at that concentration, not a potency): 82.6%
Compound 3: the middle estimate sits 27.6 percentage points below what was measured; measured number outside the range, above it.
By their numbers in this assay, from the lowest: compound 2; then compound 1; then compound 3.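

With 2,4-dimethylphenyl in place of methyl on the amide-type nitrogen, this assay shows a number 12.3 percentage points higher from compound 1 to compound 3 (beyond the scatter) and so an aromatic ring at this position can go with a stronger read-out than methyl, which compound 2 alone did not suggest. The lowering seen with phenyl therefore does not hold for both aryl groups, and the change from phenyl to 2,4-dimethylphenyl gives a number 24 percentage points higher from compound 2 to compound 3 (beyond the scatter) as the largest step in this small set, so the methyl groups on the aryl ring decide the direction among these compounds. Nothing available explains this reversal.

On these data alone, whether 2-methylphenyl or 4-methylphenyl alone would carry the gain remains open. Also open, as far as these compounds go, is how a benzyl group, a 4-chlorophenyl group or an aryl ring bearing a carboxylic acid would read at this nitrogen.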